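The compounds below may be only part of what the source reports. "The series", "measured", "known", "first", "only" and "open" are said of these compounds alone.

Measured compounds in a functional assay on SF-539 cells (Homo sapiens) for cytotoxicity, read by sulforhodamine B assay, with a stated time of 48 h; a lower number here means that less compound is tolerated, a higher number that more compound is tolerated:
compound 1 `ClCc1ccc(Cn2cnc3c(Cl)ncnc32)cc1` gives 70800 nM
compound 2 `ClCc1ccccc1Cn1cnc2ncnc(Cl)c21` gives 12000 nM
compound 3 `ClCc1ccc(Cn2cnc3c(Cl)nc(Cl)nc32)cc1` gives 56200 nM

Compound 2 has the lowest number of the three, and its steps to compound 3 and to compound 1 both lie beyond the scatter. Compound 3 differs from compound 1 by chloro in place of hydrogen on an aromatic carbon; that change gave a 1.3-fold lower number from compound 1 to compound 3 (0.10 log units; within the scatter). Compound 2 and compound 1 are built from the same atoms joined differently, and the difference between the two cores is not broken down here.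

Compound 4 `ClCc1ccccc1Cn1cnc2nc(Cl)nc(Cl)c21` has not yet been measured. It differs from compound 2 by chloro in place of hydrogen on an aromatic carbon, which is the same change as that from compound 1 to compound 3, at a place described in the same words. The step from compound 2 to compound 4 in this assay is therefore expected to be small, a 1.2-fold lower number from compound 2 to compound 4 (0.08 log units; within the scatter), because a 1.3-fold lower number from compound 1 to compound 3 (0.10 log units; within the scatter) stayed within the scatter. Compound 4 is estimated at 10000 nM, between 4000 nM and 25000 nM.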

Compound 4, concentration lethal to 50% of the cells: 8310 nM
Beside the measured number, compound 4's estimate is 1.2-fold (0.08 log units) above it; measured number inside the range.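

In this assay, chloro in place of hydrogen on an aromatic carbon gives a 1.4-fold lower number from compound 2 to compound 4 (0.16 log units; within the scatter). Set beside the earlier step on the other core, the change carries over with no difference that can be told apart: the same change on two cores in this assay, a 1.3-fold lower number (0.10 log units; within the scatter) from compound 1 to compound 3 and a 1.4-fold lower number (0.16 log units; within the scatter) from compound 2 to compound 4, 1.1-fold (0.06 log units) apart, within the scatter of two such steps. This shows only that, on these two cores, a chloro between two ring nitrogen atoms leaves the number within the scatter; it does not show that the change would stay this small on any further core.

Open, going by these compounds, is whether an amine at that same place would move the number beyond the scatter. Also open, on these data alone, is how a hydroxymethyl group in place of the chloromethyl group would read in this assay.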